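One Chlorine More on the Aromatic Ring

A few compounds are considered here, and "the series" means these few. Any claim that something is new, unique, unknown or untested is made for them only; others in the source may bear on it.

Compound 1, `Cn1c(CN2CCC(c3ccccc3)CC2)nc2ccccc21`: 6310 nM
Compound 2, `Cn1c(CN2CCN(c3ccc(C(F)(F)F)cn3)CC2)nc2ccccc21`: 6310 nM

In a functional assay on CHO cells for agonist activity at metabotropic glutamate receptor 2 (Homo sapiens), read by FLIPR (on this read-out higher numbers stand for an effect only at larger amounts of compound and lower numbers for an effect already at smaller amounts), compound 2 gives 6310 nM, level with compound 1 at the digits shown and within the scatter of the method. Compound 3, `Cn1c(CN2CCN(c3ncc(C(F)(F)F)cc3Cl)CC2)nc2ccccc21`, differs from compound 2 by chloro in place of hydrogen on an aromatic carbon. Among the measured compounds shown here, no measured pair shows what such a change does, so the expectation rests on the change alone. The expected step is modest, toward an effect at somewhat smaller amounts of compound a 2.1-fold lower number from compound 2 to compound 3 (0.32 log units; beyond the scatter). Compound 3 is therefore estimated at 3000 nM, within a range from 800 nM to 12000 nM.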

Compound 3, half-maximal effective concentration: 2000 nM
For compound 3 the middle estimate is 1.5-fold (0.18 log units) above the measured one, and the stated range covers the measured number.
By their numbers in this assay, from the lowest: compound 3; then compounds 1 and 2 (each within the scatter of the next).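

In this assay placing chloro on this aromatic carbon, ortho to a large group and two atoms from the ring nitrogen, gives a 3.2-fold lower number from compound 2 to compound 3 (0.50 log units; beyond the scatter) and is the only one-place step shown in this series. This position therefore accepts the added chlorine, and the number moves toward an effect at smaller amounts of compound. Nothing at hand explains why the number moves. From the compounds shown here alone, whether fluoro, methyl or a nitrile on the same carbon would act like chloro stays open, as does the effect of chloro on another carbon of this ring.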